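Adding an Aryl Ester to the Ether End of Compound 1

The source may report more compounds than this note shows. Statements on the series, on what has been measured and on what is new or still open speak of the compounds shown alone.

Compound 1 `COc1ccc(OCCOCCNC2CCCC2)cc1` is a phenyl ether whose chain ends in a cyclopentyl amine. In a functional assay on SK-OV-3 cells (Homo sapiens) for inhibition, read by CCK-8 assay, with a stated time of 70 h (on this read-out lower numbers stand for stronger inhibition and higher numbers for weaker inhibition), compound 1 gives 99100 nM, the highest of the two numbers recorded. Compound 2 `c1ccc(COc2ccc(OCCOCCNC3CCCCC3)cc2)cc1` gives 7370 nM; it differs from compound 1 in two places, so the two values can only be set side by side. Compound 3 `c1ccc(COc2ccc(OCCOCCNc3ccccc3)cc2)cc1` reaches only the limit > 100000 nM, a value sitting at the limit of > 100000 nM in this assay, at which 1 of the 3 values shown sits. Within the data shown here, the one single-place step, an at least 13-fold higher number from compound 2 to compound 3 (1.13 log units; beyond the scatter), concerns the amine nitrogen and not the ether end changed here. Compound 4 `COC(=O)c1cccc(COc2ccc(OCCOCCNC3CCCC3)cc2)c1` carries 3-(methoxycarbonyl)phenyl in place of hydrogen on a saturated chain carbon bound to an oxygen on an aromatic ring. Among the measured compounds shown here, no measured step covers this change; only compound 2, at 7370 nM, set beside compound 1 hints that a larger group on that oxygen goes with a lower number, so a moderate fall is expected, an 8.3-fold lower number from compound 1 to compound 4 (0.92 log units; beyond the scatter). Compound 4 is estimated at 12000 nM, between 3000 nM and 50000 nM.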

Compound 4, half-maximal inhibitory concentration: 45500 nM
Compound 4: middle estimate off by 3.8-fold (0.58 log units), on the low side; the range from low to high includes it.
By their numbers in this assay, from the lowest: compound 2; then compound 4; then compound 1. At a limit, above all of these: compound 3.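

Placing 3-(methoxycarbonyl)phenyl in place of hydrogen on a saturated chain carbon bound to an oxygen on an aromatic ring gives the first single-place step at this end of the molecule: in this assay it brings a 2.2-fold lower number from compound 1 to compound 4 (0.34 log units; beyond the scatter) and so shows that this position can carry a group of 10 heavy atoms with a modest fall in the number. Nothing measured here accounts for the size of this step.

Open, on these data alone, is what the methyl ester itself contributes, compared with an unsubstituted phenyl on the same carbon. Also open, as far as these compounds go, is how a carboxylic acid or an amide would read in its place.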